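The source may report more compounds than this note shows. Statements on the series, on what has been measured and on what is new or still open speak of the compounds shown alone.

Measured so far:
- Compound 1 `CCOc1cc(-c2ccccc2)nc2ccccc12`: 6.7 ug/mL
- Compound 2 `Oc1cc(-c2ccccc2)nc2ccc(Cl)cc12`: 0.49 ug/mL
- Compound 3 `Oc1cc(-c2ccccc2)nc2cc(F)ccc12`: < 0.1 ug/mL

All three compounds were tested in a functional assay on KB cells (Homo sapiens) for cytotoxicity; a higher number here means that more compound is needed for the effect, a lower number that less compound is needed. Compound 3 gives < 0.1 ug/mL, which is a limit of the assay and not a number. Going by the values given here, only two exact numbers are therefore available. Compound 1, at 6.7 ug/mL, holds the higher of them, and its gap to compound 2, at 0.49 ug/mL, lies beyond the scatter.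

The next compound to be measured is compound 4 `CC(C)COc1cc(-c2ccccc2)nc2ccccc12`. It departs from compound 1 by carrying isopropyl in place of methyl on a saturated chain carbon bound to an oxygen on an aromatic ring, so that ethoxy becomes isobutoxy. Among the compounds with values here, no measured pair isolates this change, so any expectation for it remains loose. In this assay, the estimated step of a 1.3-fold lower number from compound 1 to compound 4 (0.13 log units; within the scatter) is expected to stay within the scatter. Compound 4 is expected at 5 ug/mL, with an estimated range of 1.5 ug/mL to 20 ug/mL.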

Compound 4, half-maximal effective concentration: > 4 ug/mL
Compound 4 was reported as a limit (the forecaster's own chance of this, stated with the estimate: 25%); the middle value does not contradict the limit.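

In this assay compound 4 gives > 4 ug/mL, which is a limit of the assay and not a number. Going by these compounds alone, no step between compound 1 and compound 4 can be read. The compounds shown leave open whether isobutoxy in place of ethoxy changes the number at all.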